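This account rests on a few compounds, and the source may have more. Where it says the series, first, only, none or still open, it means among the compounds named here.

Measured so far:
Compound 1, `COc1ccc2c(c1)c(-c1cc(C(F)(F)F)ccn1)cn2S(=O)(=O)c1ccc(C)cc1`: in this study compound 1 gives > 100000 nM, which is a limit of the assay.
Compound 2, `Cc1ccc(S(=O)(=O)n2cc(-c3cc(C(F)(F)F)c(C#N)c(-c4cn(S(=O)(=O)c5ccc(C)cc5)c5cc(Br)ccc45)n3)c3ccc(Br)cc32)cc1`: compound 2 gives > 100000 nM, likewise a limit of the assay.

Both values come from a functional assay on A549 cells (Homo sapiens) for cytotoxicity; a lower number here means a stronger inhibitor, a higher number a weaker inhibitor. Among the measured compounds shown here, compound 1 thus stands at a limit rather than at a number in this assay, and the one further value shown is a limit as well; this is summed up by the limit of > 100000 nM in this assay, at which 2 of the 2 values shown sit, so no step between measured compounds can be sized here. Compound 3, `Cc1ccc(S(=O)(=O)n2cc(-c3cc(C(F)(F)F)ccn3)c3cc(Br)ccc32)cc1`, is the compound still to be measured. It differs from compound 1 in one place: bromo in place of methoxy on an aromatic carbon. For the measured compounds named here, no measured pair shows what such a change does in this assay. With compound 1 at the limit, the step from compound 1 to compound 3 is expected to be a number no higher from compound 1 to compound 3 (the limit leaves the size open), nothing that could be told apart from the scatter. Compound 3 is accordingly expected to give about 100000 nM in this assay, within a range of 30000 nM to 300000 nM, and most probably to be reported again only as a limit.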

Compound 3, half-maximal inhibitory concentration: 4100 nM
The estimate for compound 3 lay 24-fold (1.39 log units) above the measured number; measured number outside the range, below it.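

In this assay, this aromatic carbon, part of a fused system of two rings, proves to be a position where a single exchange can move the read-out away from the limit: bromo in place of methoxy gives an at least 24-fold lower number from compound 1 to compound 3 (1.38 log units; beyond the scatter). As far as these compounds go, the rest of the structure is the same in both compounds, so the step belongs to this one change, although its full size remains unknown with only a limit for compound 1. Compound 3 is the only compound shown with a number, and the rest of the series gives no measured value to set beside it: the limit of > 100000 nM in this assay, at which 2 of the 3 values shown sit.

The compounds shown leave open whether the step depends on bromo itself or on the loss of methoxy, which a plain hydrogen, a chloro or an amine on the same carbon would help to separate. They also leave open whether the same exchange would give a comparable step if the trifluoromethyl group were replaced by another group, such as a carboxylic acid.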